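Nitro in Place of Bromo: What Compound 4 Might Show

This account rests on a few compounds, and the source may have more. Where it says the series, first, only, none or still open, it means among the compounds named here.

Compound 1 `CC(C)=CCC1Cc2c(OCCCNS(=O)(=O)c3ccc(Br)cc3)cc(=O)n(CCCO)c2CC1(C)C` and compound 2 `CC(C)=CCC1Cc2c(OCCCNS(=O)(=O)c3ccc([N+](=O)[O-])cc3)cc(=O)n(CCCO)c2CC1(C)C` share one core and differ only by nitro in place of bromo on an aromatic carbon. In a functional assay on PANC-1 cells (Homo sapiens) for inhibition, read by MTT assay, with a stated time of 24 h, tested at 10 uM (on this read-out higher numbers stand for more inhibition at the one concentration tested (going by the name of the read-out) and lower numbers for less inhibition), compound 1 gives 19.5% and compound 2 gives 47.7%, so a number 28.2 percentage points higher from compound 1 to compound 2 (beyond the scatter). Compound 3 `CC(C)=CCC/C(C)=C/CC1Cc2c(OCCCNS(=O)(=O)c3ccc(Br)cc3)cc(=O)n(CCCO)c2CC1(C)C` has a different core, set apart from compound 1 by 3-methylbut-2-en-1-yl in place of hydrogen on a saturated chain carbon bound to a double-bonded chain carbon; in this assay compound 3 gives 15.2%, and a number 4.3 percentage points lower from compound 1 to compound 3 (within the scatter). Compound 4 `CC(C)=CCC/C(C)=C/CC1Cc2c(OCCCNS(=O)(=O)c3ccc([N+](=O)[O-])cc3)cc(=O)n(CCCO)c2CC1(C)C` differs from compound 3 by nitro in place of bromo on an aromatic carbon, the same change as that between compound 1 and compound 2, at a place described in identical words. Compound 4 is therefore expected to show a step of a number 26.8 percentage points higher from compound 3 to compound 4 (beyond the scatter) in this assay. That expectation rests on a number 28.2 percentage points higher from compound 1 to compound 2 (beyond the scatter), with the core change itself having left little mark. In this assay compound 4 is estimated at 42%, within 25% to 60%.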

Compound 4, a percentage reported as inhibition, at one concentration (the size of the read-out at that concentration, not a potency): 7.4%
For compound 4 the middle estimate is 34.6 percentage points above the measured one, and the stated range ends above it.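

In this assay, the gain seen with nitro in place of bromo on the core of compound 1 did not carry over to the other core, where the result was a number 7.8 percentage points lower from compound 3 to compound 4 (within the scatter): the same change on two cores in this assay, a number 28.2 percentage points higher (beyond the scatter) from compound 1 to compound 2 and a number 7.8 percentage points lower (within the scatter) from compound 3 to compound 4, 36 percentage points apart, beyond the scatter of two such steps Read the other way, adding 3-methylbut-2-en-1-yl made little difference with bromo present, but with nitro present it gave a number 40.3 percentage points lower from compound 2 to compound 4 (beyond the scatter): the same change on two cores in this assay, a number 4.3 percentage points lower (within the scatter) from compound 1 to compound 3 and a number 40.3 percentage points lower (beyond the scatter) from compound 2 to compound 4, 36 percentage points apart, beyond the scatter of two such steps This shows that the step on one core did not predict the step on the other, but it rests on only four compounds and does not show why the two cores differ.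

The compounds shown leave open how the two cores would respond to an amine or a nitrile on that aromatic carbon. They also leave open whether a chain of intermediate length in place of 3-methylbut-2-en-1-yl would retain the nitro gain.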